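From Fluoro to Chloro: What Compound 3 Might Show

The source may hold more compounds than are shown below. What is called first, only, known or untested is meant among the compounds shown, and "the series" means these compounds.

compound 1, `Cc1nc(-c2ccc(Cl)cc2)sc1C1SCC(=O)N1c1ccc(F)c(Cl)c1`: 65.1%
compound 2, `Cc1nc(-c2ccc(Cl)cc2)sc1C1SCC(=O)N1c1ccc(F)cc1`: 67.6%

Of the two measured compounds, compound 2 gives 67.6% in a functional assay on the whole organism (strain Wistar albino) for inhibition, with Rattus norvegicus as the target, read by paw edema, with stated times of 1 h and 4 h, at a dose of 40 mg/kg by the oral route (a higher number here means more inhibition at the dose given (going by the name of the read-out), a lower number less inhibition), and compound 1 gives 65.1%; the step of a number 2.5 percentage points higher from compound 1 to compound 2 (within the scatter) lies within the scatter, so neither stands apart from the other. Compound 3, `Cc1nc(-c2ccc(Cl)cc2)sc1C1SCC(=O)N1c1ccc(Cl)cc1`, has not yet been measured. It differs from compound 2 by chloro in place of fluoro on an aromatic carbon. Within the data shown here, no measured step exchanges fluoro for chloro. The only step shown, a number 2.5 percentage points higher from compound 1 to compound 2 (within the scatter), concerns hydrogen in place of chloro on an aromatic carbon and was within the scatter, which gives no hint of a large effect from a halogen change on this part of the molecule. On that basis the expected step of a number 1.6 percentage points lower from compound 2 to compound 3 (within the scatter) is none beyond the scatter. Compound 3 is therefore estimated at 66%, with a range from 55% to 77%.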

Compound 3, a percentage reported as inhibition, in the whole organism at one dose (the size of the read-out at that dose, not a potency): 43.2%
Beside the measured number, compound 3's estimate is 22.8 percentage points above it; measured number outside the range, below it.
By their numbers in this assay, from the lowest: compound 3; then compounds 1 and 2 (each within the scatter of the next).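

In this assay, among these compounds, the change from 4-fluorophenyl to 4-chlorophenyl gives a number 24.4 percentage points lower from compound 2 to compound 3 (beyond the scatter), which shows that the identity of the single halogen at this place, para to a large group, can matter, whereas the only earlier step, a number 2.5 percentage points higher from compound 1 to compound 2 (within the scatter), lay within the scatter. The comparison with the other fluoro-bearing compound points the same way: 4-chlorophenyl in place of 3-chloro-4-fluorophenyl gives a number 21.9 percentage points lower from compound 1 to compound 3 (beyond the scatter), so among these three compounds, the two with fluoro at this place stand together and compound 3 stands apart. Nothing available here bears on the reason for this difference. The compounds shown leave open whether the lower number is particular to chloro or extends to other groups at this place, such as bromo, methyl or methoxy. They also leave open whether an amine or a carboxylic acid there would hold the level of the fluoro compounds.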